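A few compounds are considered here, and "the series" means these few. Any claim that something is new, unique, unknown or untested is made for them only; others in the source may bear on it.

Measured compounds in a functional assay on MGC-803 cells (Homo sapiens) for inhibition, read by MTT assay, with a stated time of 48 h; a lower number here means a stronger inhibitor, a higher number a weaker inhibitor:

- compound 1, `C/C=C/C(=O)N(Cc1ccc(OC)c(C)c1)c1cc(OC)c(OC)c(OC)c1`: 14500 nM
- compound 2, `C#CC(=O)N(Cc1ccc(OC)c(O)c1)c1cc(OC)c(OC)c(OC)c1`: 170 nM
- compound 3, `COc1cc(NCc2ccccc2)cc(OC)c1OC`: > 80000 nM

Of the two numbers obtained, compound 2 has the lowest, and it is therefore the stronger inhibitor of the pair. Compound 1 sits far higher, a gap well beyond the usual scatter of this kind of measurement. For compound 3 the result is a limit of the assay rather than a number, as noted in the limit of > 80000 nM in this assay, at which 1 of the 3 values shown sits.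

Compound 4, `COc1ccc(CN(C(=O)CBr)c2cc(OC)c(OC)c(OC)c2)cc1O`, is not yet measured. It is built on compound 2 with one change at the carbonyl carbon of the amide: bromomethyl in place of ethynyl on a carbonyl carbon

No measured pair among these three compounds differs in the same way, so there is no measured step to lean on for this change. The replacement is small in atom count and leaves the rest of compound 2 untouched. Starting from compound 2 and its value of 170 nM, the step to compound 4 is expected to be modest, most likely within the scatter or only slightly toward a weaker inhibitor, giving an expected step of a 1.6-fold higher number from compound 2 to compound 4 (0.22 log units; within the scatter). Compound 4 is thus estimated at 280 nM, with a range from 60 nM to 1300 nM.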

Compound 4, half-maximal inhibitory concentration: 140 nM
The estimate for compound 4 lay 2.0-fold (0.30 log units) above the measured number; low and high end bracket the measured number.
By their numbers in this assay, from the lowest: compounds 4 and 2 (each within the scatter of the next); then compound 1. At a limit, above all of these: compound 3.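

In this assay, putting bromomethyl in place of ethynyl on a carbonyl carbon gives a 1.2-fold lower number from compound 2 to compound 4 (0.08 log units; within the scatter), so the two groups cannot be told apart at this position. This is the only measured step at this place among the compounds shown, and it shows that, in this one pair, the triple bond of ethynyl is not needed for a number of this size, since a group carrying bromine gives a matching result with the rest of the molecule unchanged. Nothing shown here explains why these two different groups read alike.

From the compounds shown here alone, whether this tolerance extends to other groups on the same carbonyl carbon stays open: a chloromethyl group, a plain methyl group or a longer chain could land close to these two compounds or far from them. Compound 1 differs from compound 2 in more than one place, so its much higher number cannot be assigned to the group on the carbonyl carbon alone, and the compounds shown do not separate that group's contribution from that of the change elsewhere in the molecule.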